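Swapping a fluorophenyl amide for a furan amide

The compounds below may be only part of what the source reports. "The series", "measured", "known", "first", "only" and "open" are said of these compounds alone.

Four compounds share one core, differing only in the acyl group on the amide nitrogen or at the carbonyl-bearing position of the thiazole. In a functional assay on Raji cells (Homo sapiens) for antiproliferative activity, read by CCK-8 assay, with a stated time of 72 h (on this read-out lower numbers stand for stronger inhibition and higher numbers for weaker inhibition), compound 1 `CN1CCN(c2ccc(Nc3nc(-c4cccc(NC(=O)c5cccc(F)c5)c4)sc3C(=O)O)cc2)CC1`, a carboxylic acid, gives 35100 nM. Compound 2 `CN1CCN(c2ccc(Nc3nc(-c4cccc(NC(=O)c5ccc(F)cc5)c4)sc3C(N)=O)cc2)CC1`, a primary amide with a 4-fluorophenyl group, gives 2820 nM. Compound 3 `CN1CCN(c2ccc(Nc3nc(-c4cccc(NC(=O)c5cccc(F)c5)c4)sc3C(N)=O)cc2)CC1`, the 3-fluorophenyl analogue of compound 2, has no number in this assay: for compound 3 the entry stands as "not determined" (no result reported), so its position rests only on its close kinship to compound 2.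

Compound 4 `CN1CCN(c2ccc(Nc3nc(-c4cccc(NC(=O)c5ccco5)c4)sc3C(N)=O)cc2)CC1` differs from compound 3 by furan-2-yl in place of 3-fluorophenyl on a carbonyl carbon. Among the compounds with values here, no measured pair shows what this exchange does here, so the expected step in this assay is small, with no clear direction and possibly none beyond the usual scatter. Taking compound 2 as the nearest anchor, compound 4 is estimated to give about 3200 nM, within a range of 800 nM to 13000 nM.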

Compound 4, half-maximal inhibitory concentration: 37400 nM
The estimate for compound 4 lay 12-fold (1.07 log units) below the measured number; measured number outside the range, above it.
By their numbers in this assay, from the lowest: compound 2; then compounds 1 and 4 (each within the scatter of the next).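

In this assay the group on this carbonyl carbon proves to matter: furan-2-yl in place of 4-fluorophenyl gives a 13-fold higher number from compound 2 to compound 4 (1.12 log units; beyond the scatter), a large change beyond the usual scatter, and the first measured sign that this position responds to swapping one aromatic ring for another. The step from compound 3 to compound 4 cannot be read, since compound 3 has no number, so the comparison rests on the 4-fluorophenyl compound alone. Nothing at hand explains the size of this step.

From the compounds shown here alone, it remains open whether 3-fluorophenyl at this position would behave like the 4-fluorophenyl group or like furan-2-yl. Also unknown is what an unsubstituted phenyl, a thiophen-2-yl or a cyclohexyl group would give on the same carbonyl carbon.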